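Compound 3 to compound 4: methylamino to propylamino

The source may hold more compounds than are shown below. What is called first, only, known or untested is meant among the compounds shown, and "the series" means these compounds.

In a functional assay on K562 cells (Homo sapiens) (a lower number here means a stronger inhibitor, a higher number a weaker inhibitor), compound 3 (`CCC(C)c1ccc(NC(=O)NC)cc1`) gives 142000 nM, the highest of the three numbers. Compound 1 (`CCCNC(=O)Nc1ccc(C(C)C)cc1`) gives 54000 nM, and compound 2 (`CCCNC(=O)Nc1ccc(C(C)(C)C)cc1`) gives 30000 nM. Compound 4 (`CCCNC(=O)Nc1ccc(C(C)CC)cc1`) differs from compound 3 by ethyl in place of hydrogen on a saturated chain carbon bound to an amide-type nitrogen, which turns methylamino into propylamino. Among the measured compounds shown here, no measured step makes this change directly. For the measured compounds named here, the only measured step, a 1.8-fold lower number from compound 1 to compound 2 (0.26 log units; within the scatter), alters the other end of the molecule and shows little sensitivity there. Compound 4 shares propylamino with compound 1 and compound 2, so its number is expected to fall near theirs. The expected change is a 3.7-fold lower number from compound 3 to compound 4 (0.57 log units; beyond the scatter), clearly beyond the scatter. Compound 4 is estimated at 38000 nM, with an expected range from 18000 nM to 80000 nM.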

Compound 4, half-maximal inhibitory concentration: 106000 nM
Compound 4: the middle estimate sits 2.8-fold (0.45 log units) below what was measured, outside the stated range (above it).
By their numbers in this assay, from the lowest: compounds 2, 1, 4 and 3 (each within the scatter of the next, the first and the last beyond it).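

In this assay, methylamino to propylamino stays within the scatter when sec-butyl is kept on the other end of the molecule (a 1.3-fold lower number from compound 3 to compound 4 (0.13 log units; within the scatter)), so propylamino alone does not set these numbers apart. With propylamino kept, the group on the aromatic carbon proves to count for more than the earlier step showed: sec-butyl in place of tert-butyl goes beyond the scatter (a 3.5-fold higher number from compound 2 to compound 4 (0.55 log units; beyond the scatter)), whereas the added methyl stays within it (a 2.0-fold higher number from compound 1 to compound 4 (0.29 log units; within the scatter)). Nothing available accounts for this difference.

From the compounds shown here alone, whether a longer chain such as pentylamino would separate from methylamino remains open. So does whether tert-butyl would keep its lower number with methylamino in place of propylamino, or whether a carboxylic acid on the propyl chain would be tolerated.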